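Replacing the sulfone at the chain end: an estimate

The compounds below may be only part of what the source reports. "The series", "measured", "known", "first", "only" and "open" are said of these compounds alone.

Going by the values given here, in an assay for inhibition of Fatty-acid amide hydrolase 1 (Rattus norvegicus) (on this read-out lower numbers stand for stronger inhibition and higher numbers for weaker inhibition), compound 2 `O=C(CCCCCS(=O)(=O)c1ccccc1)c1ncc(-c2ccccn2)o1` gives 6000 nM, the highest of the two numbers measured so far; compound 1 `CN(CCCCCC(=O)c1ncc(-c2ccccn2)o1)c1ccccc1` gives 40 nM, and the step of a 150-fold higher number from compound 1 to compound 2 (2.18 log units; beyond the scatter) shows how much the chain terminus matters. Compound 3 `O=C(CCCCCC(O)c1ccccc1)c1ncc(-c2ccccn2)o1` carries hydroxy(phenyl)methyl in place of phenylsulfonyl on a saturated chain carbon, five bonds along the chain from a carbonyl carbon. Among the compounds with values here, only that one step is available for comparison, and it was large; the change to compound 3 again replaces the group at the same position, so a sizeable step is expected. For compound 3 the estimate is 300 nM, within a range of 60 nM to 1500 nM, corresponding to an expected step of a 20-fold lower number from compound 2 to compound 3 (1.30 log units; beyond the scatter).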

Compound 3, inhibition constant: 35 nM
The estimate for compound 3 lay 8.6-fold (0.93 log units) above the measured number; measured number outside the range, below it.
By their numbers in this assay, from the lowest: compounds 3 and 1 (each within the scatter of the next); then compound 2.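

Putting hydroxy(phenyl)methyl in place of phenylsulfonyl gives a 170-fold lower number from compound 2 to compound 3 (2.23 log units; beyond the scatter) in this assay, so the poor result with phenylsulfonyl does not extend to every group carrying a phenyl ring at this place. Hydroxy(phenyl)methyl and methyl(phenyl)amino cannot be told apart here, with a 1.1-fold lower number from compound 1 to compound 3 (0.06 log units; within the scatter) inside the scatter. No evidence is available on why phenylsulfonyl stands apart from the other two groups.

Whether the hydroxy group itself matters remains open, since a plain benzyl group does not appear among these compounds. A carboxylic acid at this place, or a longer chain, is equally untested by the compounds shown.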